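This account rests on a few compounds, and the source may have more. Where it says the series, first, only, none or still open, it means among the compounds named here.

For the measured compounds named here, compound 2 `CC(C)c1ccc(-c2nc(CNc3ccc(C(=O)NO)cc3)n(-c3ccccc3)n2)cc1` stands lowest of the two numbers measured so far in an assay on Sf9 cells for inhibition of protein deacetylase HDAC6 (Homo sapiens), read by fluorescence, with a stated time of 40 min, tested at 100 nM; on this read-out lower numbers stand for less inhibition and higher numbers for more inhibition at the one concentration tested (going by the name of the read-out); in that assay compound 2 gives 27.6%, while its nearest neighbour compound 1 `COc1ccc(-c2nc(CNc3ccc(C(=O)NO)cc3)n(-c3ccccc3)n2)cc1` gives 77.6%. Going by the values given here, the one measured step, a number 50 percentage points lower from compound 1 to compound 2 (beyond the scatter), is the only guide available. Compound 3 `O=C(NO)c1ccc(NCc2nc(-c3ccsc3)nn2-c2ccccc2)cc1` differs from compound 2 by thiophen-3-yl in place of 4-isopropylphenyl on an aromatic carbon. That step touches the same aromatic carbon as the measured one but replaces a different group, so it bears only loosely on it. The group leaving is the one whose entry gave the large drop, so a rise is expected, a number 27.4 percentage points higher from compound 2 to compound 3 (beyond the scatter), and compound 3 is estimated at 55%, between 25% and 85%.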

Compound 3, a percentage reported as inhibition, at one concentration (the size of the read-out at that concentration, not a potency): 53.4%
Estimate against measurement, compound 3: 1.6 percentage points above, and the stated range covers the measured number.
By their numbers in this assay, from the lowest: compound 2; then compound 3; then compound 1.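

The aromatic carbon between two ring nitrogen atoms also accepts a five-membered aromatic ring: in this assay, thiophen-3-yl gives a number 25.8 percentage points higher from compound 2 to compound 3 (beyond the scatter), yet also a number 24.2 percentage points lower from compound 1 to compound 3 (beyond the scatter). The smaller group thus falls between 4-isopropylphenyl and 4-methoxyphenyl, so these three compounds do not order by group size alone. Nothing available here accounts for this order. From the compounds shown here alone, whether the ring size or the sulfur atom sets the level of compound 3 remains open, as both change together. An unsubstituted phenyl or a furan-3-yl at this carbon would help separate the two.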